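Hydroxy for Fluoro on the Aryl Group of Compound 3

The source may hold more compounds than are shown below. What is called first, only, known or untested is meant among the compounds shown, and "the series" means these compounds.

Measured so far:
compound 1 `OC[C@H]1OC(n2cnc3c(-c4ccco4)ncnc32)[C@H](O)[C@@H]1O` gives 2000 nM
compound 2 `OC[C@H]1OC(n2cnc3c(-c4ccccn4)ncnc32)[C@H](O)[C@@H]1O` gives 4300 nM
compound 3 `OC[C@H]1OC(n2cnc3c(-c4ccc(F)cc4)ncnc32)[C@H](O)[C@@H]1O` gives 4500 nM

All three compounds share one core and differ only in the aromatic group attached to it, and all were tested in a functional assay on L1210 cells (Mus musculus) for inhibition; on this read-out lower numbers stand for stronger inhibition and higher numbers for weaker inhibition. Compound 3 has the highest number of the three: the step of a 2.3-fold higher number from compound 1 to compound 3 (0.35 log units; beyond the scatter) lies beyond the scatter, while the step of a 1.0-fold higher number from compound 2 to compound 3 (0.02 log units; within the scatter) lies within it, so compound 2 and compound 3 cannot be told apart on this read-out.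

Compound 4 `OC[C@H]1OC(n2cnc3c(-c4ccc(O)cc4)ncnc32)[C@H](O)[C@@H]1O` is the next variation: hydroxy in place of fluoro on an aromatic carbon. For the measured compounds named here, no measured step exchanges a single substituent on the 4-fluorophenyl group; the measured steps swap the whole aromatic group, namely a 2.2-fold higher number from compound 1 to compound 2 (0.33 log units; beyond the scatter), a 2.3-fold higher number from compound 1 to compound 3 (0.35 log units; beyond the scatter) and a 1.0-fold higher number from compound 2 to compound 3 (0.02 log units; within the scatter), and all of them were modest or within the scatter. Those swaps moved the numbers little, so the expectation for compound 4 in this assay is a modest step at most, direction uncertain but leaning towards a higher number. Compound 4 is estimated at 8000 nM, with a range from 2500 nM to 30000 nM. That estimate corresponds to the expected step of a 1.8-fold higher number from compound 3 to compound 4 (0.25 log units; within the scatter).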

Compound 4, half-maximal inhibitory concentration: 5000 nM
The estimate for compound 4 lay 1.6-fold (0.20 log units) above the measured number; low and high end bracket the measured number.
By their numbers in this assay, from the lowest: compound 1; then compounds 2, 3 and 4 (each within the scatter of the next).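

In this assay, hydroxy in place of fluoro on the aromatic carbon para to a large group gives a 1.1-fold higher number from compound 3 to compound 4 (0.05 log units; within the scatter), so this first single-substituent exchange on the aryl group leaves the two compounds indistinguishable, even though hydroxy brings a hydrogen-bond donor and acceptor that fluoro lacks. The 4-hydroxyphenyl and pyridin-2-yl groups also cannot be told apart, with a 1.2-fold higher number from compound 2 to compound 4 (0.07 log units; within the scatter), while the furan-2-yl group remains separate, with a 2.5-fold higher number from compound 1 to compound 4 (0.40 log units; beyond the scatter). Nothing available here explains these results.

On these data alone, it remains open whether an amine, a carboxylic acid or a methoxy group in this same place would also stay within the scatter of compound 3. As far as these compounds go, it is equally open whether a longer chain there would give a clearly different number.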